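Swapping the Benzofuran Cap for a Dienyl Chain

The source may hold more compounds than are shown below. What is called first, only, known or untested is meant among the compounds shown, and "the series" means these compounds.

Compound 1 `CCCCCCCCNC(=O)[C@@H](NC(=O)c1cccs1)[C@@H](C)O` gives 136000 nM in a functional assay on SW-620 cells (Homo sapiens) for cytotoxicity, read by MTT assay, with a stated time of 48 h; a lower number here means a stronger inhibitor, a higher number a weaker inhibitor.
Compound 2 `CCCCCCCCNC(=O)[C@@H](NC(=O)c1cc2ccccc2o1)[C@@H](C)O` gives 200000 nM in this assay.
Compound 3 `CCCCCCCCCCCCNC(=O)[C@@H](NC(=O)c1cc2ccccc2o1)[C@@H](C)O` gives 21300 nM in this assay.

Compound 3 stands lowest of the three: compound 1 is its nearest and compound 2 its furthest, both gaps beyond the scatter. Compound 4 `C/C=C/C=C/C(=O)N[C@H](C(=O)NCCCCCCCCCCCC)[C@@H](C)O` differs from compound 3 in one place: penta-1,3-dien-1-yl in place of 1-benzofuran-2-yl on a carbonyl carbon. Among the measured compounds shown here, the only measured step at that carbonyl carbon is a 1.5-fold higher number from compound 1 to compound 2 (0.17 log units; within the scatter), which exchanged one aromatic cap for another. The step of a 9.4-fold lower number from compound 2 to compound 3 (0.97 log units; beyond the scatter) concerns the chain and does not bear here. No cap change has yet moved the number beyond the scatter, so the expected step of a 1.0-fold higher number from compound 3 to compound 4 (0.01 log units; within the scatter) is small, with wide uncertainty. Compound 4 is therefore estimated at 22000 nM, in a range from 6000 nM to 80000 nM.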

Compound 4, half-maximal inhibitory concentration: 200000 nM
Compound 4: the middle estimate sits 9.1-fold (0.96 log units) below what was measured; the whole stated range lies below it.
By their numbers in this assay, from the lowest: compound 3; then compounds 1, 2 and 4 (each within the scatter of the next).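

At this carbonyl carbon, penta-1,3-dien-1-yl in place of 1-benzofuran-2-yl gives a 9.4-fold higher number from compound 3 to compound 4 (0.97 log units; beyond the scatter) in this assay and so shows that the cap can matter here. Among the compounds shown here, the only earlier cap change, between two aromatic rings, stayed within the scatter, so this position tolerated one swap but not this one. Nothing measured here explains this step. As far as these compounds go, it remains open whether a thiophen-2-yl cap would match compound 3 on the same long chain. From the compounds shown here alone, it is also open whether a cap bearing an amine or a carboxylic acid would keep or lose the lower number.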